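Cyclobutyl to hept-6-en-1-yl on the sulfonyl side chain

The compounds below may be only part of what the source reports. "The series", "measured", "known", "first", "only" and "open" are said of these compounds alone.

In a functional assay, read by fluorescence and spectrophotometry, with a stated time of 1 h (a higher number here means that more compound is needed for the effect, a lower number that less compound is needed), compound 2 (`O=S(=O)(/C=C/c1ccc(O)c(O)c1)CC1CCC1`) gives 8800 nM. Compound 1 (`CCCCCCCCCCCCS(=O)(=O)/C=C/c1ccc(O)c(O)c1`) gives 8500 nM in the same read-out. These two numbers lie within the usual scatter of each other, so compound 2 stands level with compound 1. Among the compounds with values here, they are the only values so far, and no measured pair yet differs in a single place, so the series offers no direct measure of what one substituent change does.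

The next compound is compound 3 (`C=CCCCCCCS(=O)(=O)/C=C/c1ccc(O)c(O)c1`). Relative to compound 2 the change is hept-6-en-1-yl in place of cyclobutyl on a saturated chain carbon bound to a sulfonyl sulfur.

No step beyond the scatter is expected in this assay, in either direction. The only ground for this is that the side chains of compound 1, at 8500 nM, and compound 2, at 8800 nM, differ in structure while their values do not separate. The estimated move is a 1.0-fold lower number from compound 2 to compound 3 (0.02 log units; within the scatter). For compound 3 the expected value is 8500 nM, with an estimated range of 4000 nM to 18000 nM.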

Compound 3, half-maximal effective concentration: 6400 nM
Beside the measured number, compound 3's estimate is 1.3-fold (0.12 log units) above it; the measured number falls inside the stated range.
By their numbers in this assay, from the lowest: compounds 3, 1 and 2 (each within the scatter of the next).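

In this assay the series now has its first measures of a change in one place. Hept-6-en-1-yl in place of cyclobutyl on a saturated chain carbon bound to a sulfonyl sulfur gives a 1.4-fold lower number from compound 2 to compound 3 (0.14 log units; within the scatter) and shows that, in this pair, giving up the four-membered ring for an open chain with a double bond does not separate the values. Vinyl in place of hexyl on a saturated chain carbon, six bonds along the chain from a sulfonyl sulfur, gives a 1.3-fold lower number from compound 1 to compound 3 (0.12 log units; within the scatter) and likewise leaves the two values unseparated, while no measurement is available to explain why these side chains read alike.

Every side chain shown is built from carbon and hydrogen alone, so the effect of an amine or a carboxylic acid on this chain remains open. Going by these compounds, it is also open whether a group as small as methyl, or an aromatic phenyl, at this position would produce a step beyond the scatter.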